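The source may hold more compounds than are shown below. What is called first, only, known or untested is meant among the compounds shown, and "the series" means these compounds.

Working notes on the series. Within the data shown here, in a functional assay on L1210 cells (Mus musculus) for cytotoxicity (on this read-out higher numbers stand for weaker inhibition and lower numbers for stronger inhibition), compound 2 `COc1ccc(NC(=O)/C=C/C(=O)N2C/C(=C\c3ccccc3)C(=O)/C(=C/c3ccccc3)C2)cc1` stands at 6800 nM, the higher of the two numbers so far, while compound 1 `O=C(/C=C/C(=O)N1C/C(=C\c2ccccc2)C(=O)/C(=C/c2ccccc2)C1)Nc1ccccc1` gives 3600 nM, and the one measured step between them, a 1.9-fold higher number from compound 1 to compound 2 (0.28 log units; within the scatter), is methoxy in place of hydrogen on an aromatic carbon. Compound 3 `O=C(/C=C/C(=O)N1C/C(=C\c2ccccc2)C(=O)/C(=C/c2ccccc2)C1)Nc1ccc([N+](=O)[O-])cc1` carries nitro in place of methoxy on an aromatic carbon. Among the measured compounds shown here, no measured step involves a nitro group; the only step that bears on this change is the small one just given, so the expected change in this assay is none beyond the scatter, a 1.2-fold lower number from compound 2 to compound 3 (0.09 log units; within the scatter). Compound 3 is therefore estimated at 5500 nM, with a range from 2000 nM to 15000 nM.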

Compound 3, half-maximal inhibitory concentration: 40000 nM
Compound 3: middle estimate off by 7.3-fold (0.86 log units), on the low side, outside the stated range (above it).
By their numbers in this assay, from the lowest: compounds 1 and 2 (each within the scatter of the next); then compound 3.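

At this position, para to a large group, the number in this assay does respond to the substituent: nitro gives a 5.9-fold higher number from compound 2 to compound 3 (0.77 log units; beyond the scatter) and also an 11-fold higher number from compound 1 to compound 3 (1.05 log units; beyond the scatter), while methoxy gave only a 1.9-fold higher number from compound 1 to compound 2 (0.28 log units; within the scatter). Substitution here is therefore not neutral as a rule, and the methoxy result alone did not predict the nitro result. Nothing at hand accounts for the rise with nitro.

Open, from the compounds shown here alone, is whether an amine or a carboxylic acid here would stay with methoxy or move with nitro. Also open, going by these compounds, is whether nitro elsewhere on the ring behaves the same way.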